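A few compounds are considered here, and "the series" means these few. Any claim that something is new, unique, unknown or untested is made for them only; others in the source may bear on it.

Compounds measured so far in a toxicity assay on MT4 cells (Homo sapiens) for cytotoxicity, read by MTT assay, with a stated time of 5 days; a lower number here means that less compound is tolerated, a higher number that more compound is tolerated:

compound 1, `Cc1cc(-c2cc(C)c(Nc3ccnc(Nc4ccc(C#N)cc4)n3)c(C)c2)ccn1`: 4900 nM
compound 2, `Cc1cc(-c2ccnc(C(F)(F)F)c2)cc(C)c1Nc1ccnc(Nc2ccc(C#N)cc2)n1`: 6100 nM
compound 3, `Cc1cc(-c2cc(F)nc(F)c2)cc(C)c1Nc1ccnc(Nc2ccc(C#N)cc2)n1`: 6300 nM

All three share one core and differ only in the aromatic ring carried on it. Compound 3 sits within the scatter of both neighbours: a 1.3-fold higher number from compound 1 to compound 3 (0.11 log units; within the scatter) and a 1.0-fold higher number from compound 2 to compound 3 (0.01 log units; within the scatter), as does a 1.2-fold higher number from compound 1 to compound 2 (0.10 log units; within the scatter). None of the three exchanges of this ring has moved the number in this assay beyond the scatter.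

Compound 4, `COc1ncc(-c2cc(C)c(Nc3ccnc(Nc4ccc(C#N)cc4)n3)c(C)c2)cn1`, continues the same kind of exchange: 2-methoxypyrimidin-5-yl in place of 2,6-difluoropyridin-4-yl on an aromatic carbon. The three measured steps are the only ones that bear on it, and each of them is within the scatter, so no step beyond the scatter is expected in either direction for compound 4 in this assay. The expected step is a 1.1-fold lower number from compound 3 to compound 4 (0.02 log units; within the scatter). Compound 4 is therefore estimated at 6000 nM in this assay, with a range from 3000 nM to 12000 nM.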

Compound 4, half-maximal cytotoxic concentration: 4800 nM
The estimate for compound 4 lay 1.3-fold (0.10 log units) above the measured number, within the range that was stated.
By their numbers in this assay, from the lowest: compounds 4, 1, 2 and 3 (each within the scatter of the next).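

In this assay, 2-methoxypyrimidin-5-yl stays within the scatter of all three earlier rings (a 1.3-fold lower number from compound 3 to compound 4 (0.12 log units; within the scatter)) (a 1.3-fold lower number from compound 2 to compound 4 (0.10 log units; within the scatter)) (a 1.0-fold lower number from compound 1 to compound 4 (0.01 log units; within the scatter)). The position, on an aromatic carbon meta to two methyl groups, thus carries a ring with 2 hetero atoms and 3 hydrogen-bond acceptors with no step beyond the scatter, and all six pairs among the four compounds now lie within it. No measurement shown accounts for this flat picture.

All four groups are six-membered aromatic rings, so the series says nothing about other kinds of group at this position. As far as these compounds go, whether a carboxylic acid, an amine or a morpholine ring there would move the number beyond the scatter remains open.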